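The source may hold more compounds than are shown below. What is called first, only, known or untested is meant among the compounds shown, and "the series" means these compounds.

Compound 1 `O=C(NCCO)c1cccc2c1CCN2c1cc(Cc2cc(F)cc(C(F)(F)F)c2)ncn1` and compound 2 `O=C(NCCO)c1cccc2c1CCN2c1nccc(Cc2cc(F)cc(C(F)(F)F)c2)n1` share the same atoms joined differently; how their two cores differ is not broken down here. In a functional assay on HEK293 cells for agonist activity at G-protein coupled receptor 52 (Homo sapiens), read by cAMP accumulation, with a stated time of 15 min (on this read-out lower numbers stand for an effect already at smaller amounts and higher numbers for an effect only at larger amounts of compound), compound 1 gives 135 nM, and compound 2 gives 186 nM, two numbers within the usual scatter of each other. Compound 3 `O=C(NCCO)c1cccc2c1CCN2c1nccc(C(O)c2cc(F)cc(C(F)(F)F)c2)n1` differs from compound 2 by one change, (hydroxy in place of hydrogen on a saturated chain carbon bound to two aromatic carbons). That change made a 2.1-fold higher number from compound 2 to compound 3 (0.33 log units; beyond the scatter), so compound 3 gives 399 nM in this assay. Compound 4 `O=C(NCCO)c1cccc2c1CCN2c1cc(C(O)c2cc(F)cc(C(F)(F)F)c2)ncn1` carries the same change on the core of compound 1: hydroxy in place of hydrogen on a saturated chain carbon bound to two aromatic carbons. Because the earlier step was a 2.1-fold higher number from compound 2 to compound 3 (0.33 log units; beyond the scatter), a step of similar size is expected here, and compound 4 is estimated at 280 nM in this assay, between 150 nM and 550 nM, which means an expected 2.1-fold higher number from compound 1 to compound 4 (0.32 log units; beyond the scatter). The rest follows once the value is in hand.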

Compound 4, half-maximal effective concentration: 338 nM
The estimate for compound 4 lay 1.2-fold (0.08 log units) below the measured number; the range from low to high includes it.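

In this assay, putting hydroxy in place of hydrogen on a saturated chain carbon bound to two aromatic carbons gave a 2.5-fold higher number from compound 1 to compound 4 (0.40 log units; beyond the scatter). Set beside the earlier step, the change carried over from one core to the other with much the same size: the same change on two cores in this assay, a 2.1-fold higher number (0.33 log units; beyond the scatter) from compound 2 to compound 3 and a 2.5-fold higher number (0.40 log units; beyond the scatter) from compound 1 to compound 4, 1.2-fold (0.07 log units) apart, within the scatter of two such steps. This agreement rests on just two closely related cores and one read-out, so it does not show that the step would hold on other cores, and it does not explain why the number rises.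

The compounds shown leave open whether a different group on that same carbon, such as methoxy, an amine or fluorine, would give a similar step. Also open, on these data alone, is what a carbonyl at that carbon would do.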